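A Chloro Group Added to the Phenyl Ring of Compound 1

This account rests on a few compounds, and the source may have more. Where it says the series, first, only, none or still open, it means among the compounds named here.

Compound 1, `O=c1c2cc(Br)ccc2nc(CSc2nnc(-c3ccncc3)o2)n1/N=C/c1ccccc1`, was tested in a functional assay on the whole organism (strain Charles-Foster albino) for inhibition, with Rattus norvegicus as the target, read by paw edema, at a dose of 50 mg/kg by the oral route (a lower number here means less inhibition, a higher number more inhibition at the dose given (going by the name of the read-out)), where compound 1 gives 19.4%. Among the compounds with values here, its one measured neighbour, compound 2, `O=c1c2ccccc2nc(CSc2nnc(-c3ccncc3)o2)n1/N=C/c1ccccc1`, gives 16.3% in this assay. The two numbers lie within the usual scatter of each other, as the step of a number 3.1 percentage points lower from compound 1 to compound 2 (within the scatter) shows, so on the numbers at hand compound 1 stands level with compound 2 rather than apart from it.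

Compound 3, `O=c1c2cc(Br)ccc2nc(CSc2nnc(-c3ccncc3)o2)n1/N=C/c1ccc(Cl)cc1`, has not been measured. It differs from compound 1 in one place: chloro in place of hydrogen on an aromatic carbon. Seen one bond further out, the change reads phenyl to 4-chlorophenyl.

Within the data shown here, no measured step touches this part of the structure. Among the measured compounds shown here, the single step available, a number 3.1 percentage points lower from compound 1 to compound 2 (within the scatter), concerns a different aromatic carbon and stayed within the scatter; it tells only that one exchange of a halogen for hydrogen elsewhere on the shared core moved the number by nothing beyond the scatter. There is thus no ground for expecting a step beyond the scatter in this assay in either direction. The step of a number 0.6 percentage points higher from compound 1 to compound 3 (within the scatter) is therefore expected to stay within the scatter. Compound 3 is estimated at 20%, within a range from 9% to 31%.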

Compound 3, a percentage reported as inhibition, in the whole organism at one dose (the size of the read-out at that dose, not a potency): 26.4%
The estimate for compound 3 lay 6.4 percentage points below the measured number; low and high end bracket the measured number.
By their numbers in this assay, from the lowest: compounds 2, 1 and 3 (each within the scatter of the next, the first and the last beyond it).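

Phenyl to 4-chlorophenyl, with chloro on an aromatic carbon para to a large group, appears in this assay as a number 7 percentage points higher from compound 1 to compound 3 (within the scatter), so compound 3 stands level with compound 1 and this change gives the first reading from this part of the structure. Together with a number 3.1 percentage points lower from compound 1 to compound 2 (within the scatter), it shows that exchanges between a halogen and hydrogen at two different places on compound 1 have each stayed within the scatter, though this rests on these two steps alone. No measurement beyond this single read-out accompanies these compounds, so the data offer no explanation for either number.

The compounds shown leave open whether a methoxy group, an amine or a carboxylic acid on the same aromatic carbon would give a step beyond the scatter in this assay. They also leave open whether chloro on another carbon of this ring would read differently from the 4-chlorophenyl group of compound 3, and how any of these compounds would read at another dose.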